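The source may hold more compounds than are shown below. What is called first, only, known or untested is meant among the compounds shown, and "the series" means these compounds.

The account starts from compound 1, `Cc1cc(C)c(-c2cn(Cc3cc(-c4ccccc4)no3)nn2)cc1C`. Within the data shown here, in an ADME assay on THP-1 cells (Homo sapiens) for cytotoxicity, read by MTT assay, with a stated time of 72 h (on this read-out lower numbers stand for higher toxicity in this test and higher numbers for lower toxicity in this test), compound 1 gives 201000 nM, which is the only number reported for this small set. Compound 2, `Cc1ccc(C)c(-c2cn(Cc3cc(-c4ccccc4)no3)nn2)c1`, has no result in this assay: for compound 2 the entry reads "not determined" (no result reported). Nothing more is therefore known about where compound 1 stands relative to any other measured compound. Compound 3 is `COc1ccc(-c2cc(Cn3cc(-c4cc(C)c(C)cc4C)nn3)on2)cc1OC`. It differs from compound 1 in one place: 3,4-dimethoxyphenyl in place of phenyl on an aromatic carbon. Among the measured compounds shown here, no measured pair shows what such a change does in this assay, so the size of the step is a matter of expectation only. The expected step is small, a 1.2-fold lower number from compound 1 to compound 3 (0.07 log units; within the scatter), essentially none beyond the usual scatter, with at most a slight lean toward a lower value. Compound 3 is accordingly expected to give about 170000 nM in this assay, within a range from 60000 nM to 500000 nM.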

Compound 3, half-maximal cytotoxic concentration: > 500000 nM
Compound 3 gave a limit, no number (the forecaster's own chance of this, stated with the estimate: 30%); middle value at least 2.9-fold (0.46 log units) from the limit.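

Among these compounds, compound 3 provides the only measured change at this position: in this assay, 3,4-dimethoxyphenyl in place of phenyl on an aromatic carbon gives an at least 2.4-fold higher number from compound 1 to compound 3 (0.39 log units; beyond the scatter), a shift beyond the scatter toward lower toxicity in this test. Compound 3 reaches a limit of the assay, not a number: > 500000 nM. The full size of the step therefore stays unknown, and the direction rests on this single pair: the limit of > 500000 nM in this assay, at which 1 of the 3 values shown sits.

As far as these compounds go, whether a single methoxy group, a hydroxy group or an amine on this phenyl would shift the read-out in the same direction remains open. So does whether the change would act alike on the core of compound 2, which has no number in this assay.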